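Swapping the aryl group on the pyridazinone nitrogen of compound 3

A few compounds are considered here, and "the series" means these few. Any claim that something is new, unique, unknown or untested is made for them only; others in the source may bear on it.

Three compounds share a measured value in a functional assay on MCF7 cells (Homo sapiens) for cytotoxicity, read by MTT assay, with a stated time of 72 h; a higher number here means a weaker inhibitor, a lower number a stronger inhibitor. Compound 1 `CNC(=O)c1cc(Oc2ccc(NC(=O)c3nn(-c4ccc(Br)cc4F)c(=O)cc3C)cc2F)ccn1` gives 9360 nM. Compound 2 `CNC(=O)c1cc(Oc2ccc(NC(=O)c3nn(-c4cccc(F)c4)c(=O)cc3C)cc2F)ccn1` gives 6410 nM, and the change from the first to the second, a 3-fluorophenyl in place of a 4-bromo-2-fluorophenyl on an aromatic nitrogen, is a 1.5-fold lower number from compound 1 to compound 2 (0.16 log units; within the scatter). Compound 3 `Cc1cc(=O)n(-c2ccccc2C(F)(F)F)nc1C(=O)Nc1ccc(Oc2ncnc3ccsc23)cc1` gives 5550 nM, the lowest number of the three, although both its gaps to compound 1 and to compound 2 lie within the scatter, so no ranking among them can be drawn.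

Compound 4 `Cc1ccc(-n2nc(C(=O)Nc3ccc(Oc4ncnc5ccsc45)cc3)c(C)cc2=O)c(C)c1` differs from compound 3 in one place: 2,4-dimethylphenyl in place of 2-(trifluoromethyl)phenyl on an aromatic nitrogen. Within the data shown here, the only measured step that bears on this kind of change, an exchange of the aryl group on the aromatic nitrogen, is the one from compound 1 to compound 2, and that step stayed within the scatter. On that basis compound 4 is expected to show no step beyond the scatter in this assay, with an estimated step of a 1.0-fold lower number from compound 3 to compound 4 (0.00 log units; within the scatter). The estimate for compound 4 is 5500 nM, with a range from 2000 nM to 16000 nM.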

Compound 4, half-maximal inhibitory concentration: 11900 nM
Compound 4: middle estimate off by 2.2-fold (0.34 log units), on the low side, within the range that was stated.
By their numbers in this assay, from the lowest: compounds 3, 2, 1 and 4 (each within the scatter of the next, the first and the last beyond it).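

Among these compounds, on the core of compound 3, the aryl group on the aromatic nitrogen moves the number beyond the scatter in this assay (a 2.1-fold higher number from compound 3 to compound 4 (0.33 log units; beyond the scatter)), whereas the one earlier exchange at this position, on a different core, stayed within it (a 1.5-fold lower number from compound 1 to compound 2 (0.16 log units; within the scatter)). The step is modest, and it comes from replacing 2-(trifluoromethyl)phenyl, with 10 heavy atoms including 3 fluorine, by 2,4-dimethylphenyl, with 8 heavy atoms, all carbon. No measurement given here ties this step to any property of either group.

The single step removes the trifluoromethyl group and brings in two methyl groups together, so the compounds shown do not separate these changes. On these data alone, how an aryl group carrying an amine or a carboxylic acid, or a longer chain on this nitrogen, would behave remains open.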